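From 4-fluorophenyl to 3-chlorophenyl on compound 3

The source may report more compounds than this note shows. Statements on the series, on what has been measured and on what is new or still open speak of the compounds shown alone.

Measured in a functional assay on MCF7 cells (Homo sapiens) for inhibition, read by sulforhodamine B assay; on this read-out lower numbers stand for stronger inhibition of growth and higher numbers for weaker inhibition of growth:
Compound 1 `Fc1ccc(-c2ccc(-c3ccc(-c4nc5ccccc5[nH]4)cc3)cc2)cc1`: 36200 nM
Compound 2 `COc1ccc(-c2ccc(-c3ccc(-c4nc5ccccc5[nH]4)cc3)cc2)cc1OC`: 7600 nM
Compound 3 `Oc1cccc2[nH]c(-c3ccc(-c4ccc(-c5ccc(F)cc5)cc4)cc3)nc12`: 3010 nM

Compound 3 has the lowest number of the three. Adding a hydroxy in place of hydrogen on an aromatic carbon gave a 12-fold lower number from compound 1 to compound 3 (1.08 log units; beyond the scatter). That hydroxy stays in compound 4 `Oc1cccc2[nH]c(-c3ccc(-c4ccc(-c5cccc(Cl)c5)cc4)cc3)nc12`, so this large step does not bear directly on the next change. Instead, one group is replaced: 3-chlorophenyl in place of 4-fluorophenyl on an aromatic carbon. In words, this is 3-chlorophenyl in place of 4-fluorophenyl on an aromatic carbon.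

Among the compounds with values here, the closest precedent also removes 4-fluorophenyl: putting 3,4-dimethoxyphenyl there gave a 4.8-fold lower number from compound 1 to compound 2 (0.68 log units; beyond the scatter). This modest step shows that swapping this group can shift the number, but it was made without the hydroxy and with a different incoming group. Within the data shown here, no measured compound carries chlorine, so the direction remains uncertain. The expected step in this assay is small, and the estimate is a 1.2-fold lower number from compound 3 to compound 4 (0.08 log units; within the scatter). For compound 4 the estimated value is 2500 nM, with an expected range from 800 nM to 8000 nM.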

Compound 4, concentration for 50% growth inhibition: 3420 nM
Beside the measured number, compound 4's estimate is 1.4-fold (0.14 log units) below it; the range from low to high includes it.
By their numbers in this assay, from the lowest: compounds 3 and 4 (each within the scatter of the next); then compound 2; then compound 1.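

In this assay, putting 3-chlorophenyl in place of 4-fluorophenyl with the hydroxy kept gave a 1.1-fold higher number from compound 3 to compound 4 (0.06 log units; within the scatter). With the hydroxy present, then, these two groups cannot be told apart on this read-out, so this change leaves growth inhibition effectively where it was. The earlier step to 3,4-dimethoxyphenyl could not show this, since it was read without the hydroxy and it moved the number beyond the scatter. Nothing available explains why the two groups read alike.

As far as these compounds go, it remains open whether 3,4-dimethoxyphenyl would still lower the number with the hydroxy present, and whether the hydroxy gives the same gain alongside 3-chlorophenyl as alongside 4-fluorophenyl. The effect of a phenyl group carrying an amine or a carboxylic acid at this position is also unknown.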